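The source may report more compounds than this note shows. Statements on the series, on what has been measured and on what is new or still open speak of the compounds shown alone.

Measured so far in an assay on isolated protein for inhibition of Amine oxidase [flavin-containing] A (Homo sapiens), read by fluorescence, with a stated time of 20 min; on this read-out lower numbers stand for stronger inhibition and higher numbers for weaker inhibition:
compound 1 `CC(C)=NNc1nc(-c2cccc([N+](=O)[O-])c2)cs1` gives 1070 nM
compound 2 `CCC(CC)=NNc1nc(-c2cccc([N+](=O)[O-])c2)cs1` gives 24300 nM
compound 3 `CCC/C(CC)=N\Nc1nc(-c2cccc([N+](=O)[O-])c2)cs1` gives 4860 nM

Compound 3 stands second highest of the three numbers, between compound 1 and compound 2. Compound 4 `CCCCC/C(CC)=N\Nc1nc(-c2cccc([N+](=O)[O-])c2)cs1` differs from compound 3 by ethyl in place of hydrogen on a saturated chain carbon, three bonds along the chain from a carbon with a double bond to nitrogen. Among the compounds with values here, two steps bear on chain lengthening here: a 23-fold higher number from compound 1 to compound 2 (1.36 log units; beyond the scatter) and a 4.5-fold higher number from compound 1 to compound 3 (0.66 log units; beyond the scatter) both went to higher numbers, whereas a 5.0-fold lower number from compound 2 to compound 3 (0.70 log units; beyond the scatter) went to a lower number. The direction is therefore not settled, and the expected step in this assay is small, within or near the scatter. For compound 4 the estimated step is a 1.4-fold lower number from compound 3 to compound 4 (0.14 log units; within the scatter), giving an expected value of 3500 nM with a range of 1000 nM to 12000 nM.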

Compound 4, half-maximal inhibitory concentration: 7150 nM
The estimate for compound 4 lay 2.0-fold (0.31 log units) below the measured number; low and high end bracket the measured number.
By their numbers in this assay, from the lowest: compound 1; then compounds 3 and 4 (each within the scatter of the next); then compound 2.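

In this assay, the propyl to pentyl change gives a 1.5-fold higher number from compound 3 to compound 4 (0.17 log units; within the scatter), so this longer chain, three bonds along from the carbon with a double bond to nitrogen, leaves the number within the scatter. The lower number seen with the first lengthening of the ethyl chain persists, at a 3.4-fold lower number from compound 2 to compound 4 (0.53 log units; beyond the scatter), although this gain is smaller than the earlier step of a 5.0-fold lower number from compound 2 to compound 3 (0.70 log units; beyond the scatter) as printed. On these data alone, whether a chain longer than pentyl, or an amine or carboxylic acid on this chain, would keep the number at this level remains open. Nothing at hand explains these steps.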